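Series notes: chloro substitution and cytotoxicity in A549 cells

A few compounds are considered here, and "the series" means these few. Any claim that something is new, unique, unknown or untested is made for them only; others in the source may bear on it.

Measured compounds in a functional assay on A549 cells (Homo sapiens) for cytotoxicity, read by MTT assay, with a stated time of 72 h; a lower number here means a stronger inhibitor, a higher number a weaker inhibitor:
Compound 1, `O=C(Nc1nc2ccccc2s1)c1cn(-c2ccccc2)nc1-c1ccccc1`, gives 13500 nM.
Compound 2, `O=C(Nc1nc2ccc(Cl)cc2s1)c1cn(-c2ccccc2)nc1-c1ccccc1`, gives 7670 nM.
Compound 3, `Cc1ccc2nc(NC(=O)c3cn(-c4ccccc4)nc3-c3ccccc3)sc2c1`, gives 26500 nM.

Compound 1 stands second highest of the three numbers. Its nearest neighbour is compound 2, reached by the step of a 1.8-fold lower number from compound 1 to compound 2 (0.25 log units; within the scatter), which is within the scatter; the step of a 2.0-fold higher number from compound 1 to compound 3 (0.29 log units; within the scatter) is likewise within the scatter. Within the data shown here, the only step beyond the scatter is a 3.5-fold higher number from compound 2 to compound 3 (0.54 log units; beyond the scatter), and that one is modest.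

Compound 4, `O=C(Nc1nc2ccccc2s1)c1cn(-c2ccccc2)nc1-c1ccc(Cl)cc1`, differs from compound 1 by chloro in place of hydrogen on an aromatic carbon; the same difference, cut one bond further out, reads phenyl to 4-chlorophenyl. Among the measured compounds shown here, no measured step touches this ring: the chloro of compound 2 and the methyl of compound 3 both sit on the shared core. The closest analogy is the step of a 1.8-fold lower number from compound 1 to compound 2 (0.25 log units; within the scatter), a chloro entering at another place, which stayed within the scatter. On that basis the expected step of a 1.4-fold lower number from compound 1 to compound 4 (0.13 log units; within the scatter) is small, with no direction that can be claimed beyond the scatter, leaning if anything toward a lower number. Compound 4 is therefore estimated at 10000 nM, with a range from 4000 nM to 25000 nM in this assay.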

Compound 4, half-maximal inhibitory concentration: 10300 nM
Estimate against measurement, compound 4: 1.0-fold (0.01 log units) below; low and high end bracket the measured number.
By their numbers in this assay, from the lowest: compounds 2, 4, 1 and 3 (each within the scatter of the next, the first and the last beyond it).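

Among these compounds, the step of a 1.3-fold lower number from compound 1 to compound 4 (0.12 log units; within the scatter) is a reading on a ring that none of the earlier steps touched, and in this assay phenyl to 4-chlorophenyl at this carbon, para to a large group, stays within the scatter. Chloro has now entered compound 1 at two separate places, the other being the step of a 1.8-fold lower number from compound 1 to compound 2 (0.25 log units; within the scatter) on the shared core, and neither step leaves the scatter, so in these compounds neither place shows a measurable response to chloro. No evidence is available that bears on this result.

As far as these compounds go, whether this position responds to anything other than chloro remains open, since a single small substituent cannot show what an amine, a carboxylic acid or a longer chain such as butyl would do at the same carbon. Also open, from the compounds shown here alone, are the remaining carbons of this ring and the other phenyl of the shared core, and whether a step beyond the scatter can be reached from either.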